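Dibutylamino to tert-butylamino on the second core

The source may report more compounds than this note shows. Statements on the series, on what has been measured and on what is new or still open speak of the compounds shown alone.

Two cores carry the same aryloxypropylamine side chain. Compound 3 `CCCCN(CCCC)CCCOc1ccc(S(=O)(=O)c2c(C(C)C)cc3ccccn23)cc1` and compound 1 `CC(C)c1cc2ccccn2c1S(=O)(=O)c1ccc(OCCCNC(C)(C)C)cc1` share one core; compound 2 `CCCCN(CCCC)CCCOc1ccc(S(=O)(=O)c2cc3ccccc3nc2C(C)C)cc1` and the as yet unmeasured compound 4 `CC(C)c1nc2ccccc2cc1S(=O)(=O)c1ccc(OCCCNC(C)(C)C)cc1` share the other. How the two cores differ is not broken down here, so compound 2 is set beside compound 3 only by their numbers.

In a functional assay (aorta) for inhibition, with Rattus norvegicus as the target (a lower number here means a stronger inhibitor, a higher number a weaker inhibitor), compound 3 gives 13.3 nM, and compound 1 gives 32.9 nM. Going by the values given here, the one change between them, ((tert-butyl)amino in place of dibutylamino on a saturated chain carbon, three bonds along the chain from an oxygen on an aromatic ring), made a 2.5-fold higher number from compound 3 to compound 1 (0.39 log units; beyond the scatter). Compound 2, carrying the dibutylamino chain on the second core, gives 198 nM in this assay, the highest number among the three measured compounds; its gaps to compound 1 and to compound 3 both lie beyond the scatter.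

Compound 4 arises from compound 2 by (tert-butyl)amino in place of dibutylamino on a saturated chain carbon, three bonds along the chain from an oxygen on an aromatic ring. The place of this change is the same, word for word, as the place of the change from compound 3 to compound 1, so it is the same change carried onto the second core. Among the compounds with values here, only one earlier instance exists, on a different core, so the transfer is uncertain. Within the data shown here, the expectation for compound 4 in this assay is that the step from compound 2 will be a 2.4-fold higher number from compound 2 to compound 4 (0.38 log units; beyond the scatter), resting on the single step from compound 3 to compound 1. Compound 4 is accordingly estimated at 480 nM, with a likely range from 180 nM to 1300 nM.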

Compound 4, half-maximal inhibitory concentration: 370 nM
Beside the measured number, compound 4's estimate is 1.3-fold (0.11 log units) above it; measured number inside the range.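

Carried onto the core of compound 2, (tert-butyl)amino in place of dibutylamino gives in this assay a 1.9-fold higher number from compound 2 to compound 4 (0.27 log units; within the scatter), so on this core alone the two compounds cannot be told apart. Set beside the earlier step, the new one does not differ from it: the same change on two cores in this assay, a 2.5-fold higher number (0.39 log units; beyond the scatter) from compound 3 to compound 1 and a 1.9-fold higher number (0.27 log units; within the scatter) from compound 2 to compound 4, 1.3-fold (0.12 log units) apart, within the scatter of two such steps

This supports reading the exchange as transferable across these two cores, with a similar step on each, but it does not establish a real step on the core of compound 2, and two pairs say nothing about a further core or about what lies behind the step.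

The compounds shown leave open how other amines on the same chain would behave on both cores, for example a ring amine such as piperidine, a small secondary amine such as isopropylamino, or a dimethylamino group. They also leave open whether the step holds with a longer chain carrying the amine, or whether a primary amine at the chain end would keep the two cores in step.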